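Phenyl for tert-butoxycarbonyl on the piperazine amide

The compounds below may be only part of what the source reports. "The series", "measured", "known", "first", "only" and "open" are said of these compounds alone.

Measured so far in a functional assay on MDA-MB-231 cells (Homo sapiens) for inhibition, read by sulforhodamine B assay, with a stated time of 48 h; a higher number here means a weaker inhibitor of growth, a lower number a stronger inhibitor of growth:
compound 1 `CC(C)(C)OC(=O)N1CCN(C(=O)CCN2C(=O)CSc3ccccc32)CC1` — > 100000 nM
compound 2 `O=C(CCN1C(=O)CSc2ccccc21)N1CCC(Cc2ccccc2)CC1` — 3800 nM

Compound 1 stands only at a limit in this assay: the value > 100000 nM is a limit of the assay and not a number, which the limit of > 100000 nM in this assay, at which 1 of the 2 values shown sits, records. Within the data shown here, compound 2 is the one measured compound with a number, and in this assay compound 2 gives 3800 nM. Among the measured compounds shown here, no step between two measured compounds is available, so nothing measured connects compound 1 and compound 2 by a single change.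

Compound 3 `O=C(CCN1C(=O)CSc2ccccc21)N1CCN(c2ccccc2)CC1` has not yet been measured in this assay. It differs from compound 1 by phenyl in place of tert-butoxycarbonyl on an amine nitrogen in a ring, in words: phenyl in place of tert-butoxycarbonyl on an amine nitrogen in a ring.

Since compound 1 sits at a limit, any measurable number for compound 3 can only appear as a move toward stronger growth inhibition, and a step beyond the scatter in that direction is expected. Compound 3 is estimated at 6000 nM, with a range of 1500 nM to 40000 nM. The expected step is an at least 16-fold lower number from compound 1 to compound 3 (1.22 log units; beyond the scatter).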

Compound 3, concentration for 50% growth inhibition: 5400 nM
For compound 3 the middle estimate is 1.1-fold (0.05 log units) above the measured one; the range from low to high includes it.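

In this assay, among these compounds, phenyl in place of tert-butoxycarbonyl on the amine nitrogen in the ring of the piperazine amide gives an at least 18-fold lower number from compound 1 to compound 3 (1.26 log units; beyond the scatter), the first step that can be read. With the shared core unchanged, this single change on that nitrogen moves the compound from a limit to a measured number, so the group at this position clearly matters for growth inhibition. For compound 1 the value > 100000 nM is a limit of the assay and not a number, so the step gives only a bound and its true size stays unknown: the limit of > 100000 nM in this assay, at which 1 of the 3 values shown sits.

This one pair cannot tell whether the step follows the aromatic ring that enters or the carbonyl and the oxygens that leave, and a cyclohexyl, benzyl or acetyl group on the same nitrogen would help to separate the two. As far as these compounds go, compound 2 differs from compound 3 in more than one place, so how the piperazine amide compares with the benzyl-bearing ring of compound 2 also stays open.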